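What to expect from compound 3 to compound 4

This account rests on a few compounds, and the source may have more. Where it says the series, first, only, none or still open, it means among the compounds named here.

In a functional assay on the whole organism with Rattus norvegicus as the target (on this read-out higher numbers stand for an effect only at larger amounts of compound and lower numbers for an effect already at smaller amounts), compound 3 `C[S+]([O-])Cn1c(=N)sc2cc(OC(F)(F)F)ccc21` gives 2.3 mg/kg, the lower of the two actual numbers. Compound 1 `N=c1sc2cc(OC(F)(F)F)ccc2n1CCS(N)(=O)=O` gives 6 mg/kg, and the step between them is a 2.6-fold lower number from compound 1 to compound 3 (0.42 log units; beyond the scatter). Compound 2 `CN(C)S(=O)(=O)CCn1c(=N)sc2cc(OC(F)(F)F)ccc21` gives > 10 mg/kg, which is a limit of the assay and not a number. The step from that limit is an at least 4.3-fold lower number from compound 2 to compound 3 (0.63 log units; beyond the scatter), while the other step among these compounds is an at least 1.6-fold higher number from compound 1 to compound 2 (0.22 log units; that floor lies within the scatter).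

The change to compound 4 `CSCCn1c(=N)sc2cc(OC(F)(F)F)ccc21` is a group of 3 heavy atoms (2 carbon, 1 sulfur; no ring) in place of a group of 3 heavy atoms (1 carbon, 1 oxygen, 1 sulfur; no ring), on a saturated chain carbon bound to an aromatic nitrogen and brings in (methylsulfanyl)methyl on a saturated chain carbon bound to an aromatic nitrogen. The two steps that end at compound 3 changed this same place and were modest in size, but neither tests this exchange. They offer no firm direction, so only a small move is expected. The estimated step is a 1.3-fold higher number from compound 3 to compound 4 (0.12 log units; within the scatter), and no change beyond the scatter is expected. The estimate for compound 4 is 3 mg/kg, with an expected range from 1 mg/kg to 9 mg/kg.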

Compound 4, dose for half-maximal effect: 1 mg/kg
Compound 4: middle estimate off by 3.0-fold (0.48 log units), on the high side; the range from low to high includes it.
By their numbers in this assay, from the lowest: compound 4; then compound 3; then compound 1. At a limit, above all of these: compound 2.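

In this assay, the exchange on a saturated chain carbon bound to an aromatic nitrogen gives a 2.3-fold lower number from compound 3 to compound 4 (0.36 log units; beyond the scatter), showing that the number at this place can fall further than compound 3 had shown. Methylsulfanyl in place of sulfamoyl gives a 6.0-fold lower number from compound 1 to compound 4 (0.78 log units; beyond the scatter), and methylsulfanyl in place of dimethylsulfamoyl gives an at least 10-fold lower number from compound 2 to compound 4 (1.00 log units; beyond the scatter), which leaves compound 4 lowest of the four. Compound 2 stands at a limit of the assay and not a number, so its step is only a floor: the limit of > 10 mg/kg in this assay, at which 1 of the 4 values shown sits.

The compounds shown leave open whether the sulfur itself matters, which a methoxy group or a plain alkyl chain at this place would test. They also leave open whether a longer chain carrying methylsulfanyl would hold this result.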